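The compounds below may be only part of what the source reports. "The series", "measured", "known", "first", "only" and "open" are said of these compounds alone.

In a functional assay on HL-60 cells (Homo sapiens) for inhibition, read by MTT assay, with a stated time of 72 h (on this read-out lower numbers stand for stronger inhibition and higher numbers for weaker inhibition), compound 1 `Cc1nc(-c2ccc(F)cc2)c(C(=O)N2CCN(c3cccc(Cl)c3)CC2)o1` gives 40.1 nM and compound 3 `CCc1nc(-c2ccc(F)cc2)c(C(=O)N2CCN(c3cccc(Cl)c3)CC2)o1` gives 169 nM, the higher of the two numbers. Going by the values given here, compound 2 `O=C(c1oc(C(F)(F)F)nc1-c1cccc(F)c1)N1CCN(c2cccc(Cl)c2)CC1`, the only measured compound with 3-fluorophenyl, gives "not active" (no number reported). Compound 4 `CCc1nc(-c2cccc(F)c2)c(C(=O)N2CCN(c3cccc(Cl)c3)CC2)o1` keeps the ethyl group of compound 3 and carries 3-fluorophenyl in place of 4-fluorophenyl on an aromatic carbon. Among the compounds with values here, the one measured step, a 4.2-fold higher number from compound 1 to compound 3 (0.62 log units; beyond the scatter), lies at the ethyl group and not at this place, so it offers only a rough scale. Within the data shown here, since compound 2 gives "not active" (no number reported), a modest step towards a higher number is expected, though no measured step covers this change. The expected step is a 1.5-fold higher number from compound 3 to compound 4 (0.19 log units; within the scatter). Compound 4 is estimated at 260 nM, with an expected range of 70 nM to 1000 nM.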

Compound 4, half-maximal inhibitory concentration: 317 nM
For compound 4 the middle estimate is 1.2-fold (0.09 log units) below the measured one; low and high end bracket the measured number.
By their numbers in this assay, from the lowest: compound 1; then compounds 3 and 4 (each within the scatter of the next).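

Moving the fluorine on the aryl group at this position, on the carbon next to the ring nitrogen, gives in this assay a 1.9-fold higher number from compound 3 to compound 4 (0.27 log units; within the scatter) and so does not separate the two fluorophenyl isomers. Compound 4 keeps a measurable number with 3-fluorophenyl, whereas compound 2 reads "not active" (no number reported) with the same aryl group and trifluoromethyl in place of ethyl, so that reading cannot be set on 3-fluorophenyl alone.

Still open, on these data alone, are how a plain phenyl or a methoxyphenyl would read at this position and whether the fluorine shift reads the same with methyl in place of ethyl. No evidence at hand explains the result.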